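Methyl-for-hydrogen steps in a kinase inhibitor series

The source may hold more compounds than are shown below. What is called first, only, known or untested is meant among the compounds shown, and "the series" means these compounds.

Measured compounds:
compound 1, `Cc1ccc(NCN2C(=O)c3ccccc3C2=O)cc1`, 4300 nM
compound 2, `CCc1ccc(NCN2C(=O)c3ccccc3C2=O)cc1`, 4310 nM
compound 3, `COc1ccc(NCN2C(=O)c3cccc(NC(=O)c4ccccc4)c3C2=O)cc1`, 990 nM

All three were run in an assay on isolated protein for inhibition of ribosomal protein S6 kinase alpha-2 (Homo sapiens), read by fluorescence, with a stated time of 20 min; on this read-out lower numbers stand for stronger inhibition and higher numbers for weaker inhibition. Compound 1 and compound 2 share one core; the change between them is methyl in place of hydrogen on a saturated chain carbon bound to an aromatic carbon, and it gives a 1.0-fold higher number from compound 1 to compound 2 (0.00 log units; within the scatter). Compound 3 carries a different core; the difference between the two cores is not broken down here. Compound 3 gives the lowest of the three numbers, and its step to compound 1 as well as to compound 2 lies beyond the scatter.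

Compound 4, `CCOc1ccc(NCN2C(=O)c3cccc(NC(=O)c4ccccc4)c3C2=O)cc1`, has not yet been measured in this assay. It differs from compound 3 by methyl in place of hydrogen on a saturated chain carbon bound to an oxygen on an aromatic ring. Within the data shown here, this is the same kind of change as the one from compound 1 to compound 2, but not the same: there the saturated chain carbon is bound to an aromatic carbon, here to an oxygen on an aromatic ring. For compound 4 the expected step is a 1.0-fold higher number from compound 3 to compound 4 (0.00 log units; within the scatter). Among the measured compounds shown here, that expectation rests on a 1.0-fold higher number from compound 1 to compound 2 (0.00 log units; within the scatter), the only measured step of this kind, which is flat; a single example on a different core is a thin basis, so the range is kept wide. Compound 4 is accordingly estimated at 1000 nM, between 450 nM and 2300 nM.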

Compound 4, half-maximal inhibitory concentration: 1340 nM
Compound 4: the middle estimate sits 1.3-fold (0.13 log units) below what was measured; the range from low to high includes it.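

In this assay the change from methoxy to ethoxy gives a 1.4-fold higher number from compound 3 to compound 4 (0.13 log units; within the scatter), so on this core too the added methyl produces no step beyond the scatter. Set beside the earlier methyl-for-hydrogen step, the two cores show no difference that can be told from scatter: the same change on two cores in this assay, a 1.0-fold higher number (0.00 log units; within the scatter) from compound 1 to compound 2 and a 1.4-fold higher number (0.13 log units; within the scatter) from compound 3 to compound 4, 1.4-fold (0.13 log units) apart, within the scatter of two such steps. Among these compounds, this supports carrying the change between these two cores without a measurable penalty, but it rests on only two pairs, and since the methyl sits on a saturated chain carbon bound to an aromatic carbon in one pair and on one bound to an oxygen on an aromatic ring in the other, core and place cannot be separated, nor does it give a rule for any further core.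

The compounds shown leave open whether a longer chain, such as propoxy or butoxy, or a branched isopropoxy group would stay as flat on the core of compound 3. They also leave open what an amine or a carboxylic acid at the end of that chain would do.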